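Shortening an Amino Side Chain: Compound 2 to Compound 3

The source may report more compounds than this note shows. Statements on the series, on what has been measured and on what is new or still open speak of the compounds shown alone.

Measured so far in a functional assay on EL4 cells (Mus musculus) for inhibition, tested at 100 uM; on this read-out higher numbers stand for more inhibition at the one concentration tested (going by the name of the read-out) and lower numbers for less inhibition:
compound 1 `CSc1nccc2c1ncn2C1O[C@H](CO)[C@@H](O)[C@H]1O` gives < 5%.
Compound 2 `OCCNc1nccc2c1ncn2C1O[C@H](CO)[C@@H](O)[C@H]1O` gives 6%.

The value of compound 1 is a limit of the assay, not a number (the limit of < 5% in this assay, at which 1 of the 2 values shown sits). Compound 2 holds the only number shown. The step between them, a number at least 1 percentage points higher from compound 1 to compound 2 (that floor lies within the scatter), exchanges (2-hydroxyethyl)amino for methylsulfanyl on an aromatic carbon.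

Compound 3 `CNc1nccc2c1ncn2C1O[C@H](CO)[C@@H](O)[C@H]1O` differs from compound 2 by hydrogen in place of hydroxymethyl on a saturated chain carbon bound to a nitrogen on an aromatic ring. No measured step touches this chain, and the one step shown stays within scatter, so no step beyond the scatter is expected: a number 1 percentage points lower from compound 2 to compound 3 (within the scatter). Compound 3 is estimated at 5%, between 0% and 15%.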

Compound 3, a percentage reported as inhibition, at one concentration (the size of the read-out at that concentration, not a potency): 11%
Estimate against measurement, compound 3: 6 percentage points below; low and high end bracket the measured number.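

In this assay, the step is a number 5 percentage points higher from compound 2 to compound 3 (within the scatter), so at this position the (2-hydroxyethyl)amino and methylamino groups cannot be told apart. The value of compound 1 is a limit of the assay, not a number. Methylamino in place of methylsulfanyl gives a number at least 6 percentage points higher from compound 1 to compound 3 (that floor lies within the scatter), so this exchange also shows no change beyond the scatter.

As far as these compounds go, what a longer chain, a benzyl group or a carboxylic acid would do here remains open. So does whether any group at this position can move inhibition beyond the scatter.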